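The source may report more compounds than this note shows. Statements on the series, on what has been measured and on what is new or still open speak of the compounds shown alone.

Compound 1 `Cc1nc(SCC(=O)Nc2nc(-c3ccc(Cl)cc3)cs2)n(Nc2ccccc2)c1C` is the anchor of this small set. Among the measured compounds shown here, in a functional assay on U-251 cells (Homo sapiens) for antiproliferative activity, read by sulforhodamine B assay, with a stated time of 48 h (on this read-out higher numbers stand for weaker inhibition of growth and lower numbers for stronger inhibition of growth), compound 1 gives 13000 nM, the only plain number among the values shown. For the measured compounds named here, compound 2 `Cc1ccc(Nn2c(SCC(=O)Nc3nc(-c4ccccc4)cs3)nc(C)c2C)cc1` differs from compound 1 in two places at once, so no single step between the two can be read from their values. In this assay compound 2 gives > 100000 nM, which is a limit of the assay rather than a measured number, as the limit of > 100000 nM in this assay, at which 1 of the 2 values shown sits, records. Compound 3 `COc1ccc(Nn2c(SCC(=O)Nc3nc(-c4ccc(Cl)cc4)cs3)nc(C)c2C)cc1` is compound 1 with one change: methoxy in place of hydrogen on an aromatic carbon, the incoming group sitting on an aromatic carbon of a six-membered aromatic ring of carbon only, para to a large group. Going by the values given here, no measured pair shows this change on its own, so the step of a 1.4-fold higher number from compound 1 to compound 3 (0.14 log units; within the scatter) is expected to stay within the usual scatter, in no particular direction. Compound 3 is therefore estimated at 18000 nM, with a range from 5000 nM to 80000 nM.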

Compound 3, concentration for total growth inhibition: > 100000 nM
Compound 3: a limit, no number (the forecaster's own chance of this, stated with the estimate: 30%); middle value at least 5.5-fold (0.74 log units) away from the limit.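

In this assay, replacing hydrogen with methoxy on the aromatic carbon para to a large group, which turns phenyl into 4-methoxyphenyl, gives an at least 7.6-fold higher number from compound 1 to compound 3 (0.88 log units; beyond the scatter). Among the compounds shown here, this is the first single change that can be read in this set, and it shows that growth inhibition at this position weakens beyond the scatter. Compound 3 gives > 100000 nM, which is a limit of the assay and not a number, so the true size of the step remains unknown: the limit of > 100000 nM in this assay, at which 2 of the 3 values shown sit.

As far as these compounds go, whether this loss is specific to methoxy or would follow other replacements of this hydrogen remains open, since only one replacement at this position can be read. A fluorine atom, a hydroxyl group or an amino group in the same place could give a different result.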